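The compounds below may be only part of what the source reports. "The series", "measured", "known", "first", "only" and "open" are said of these compounds alone.

Values measured so far in a functional assay on HepG2 cells (Homo sapiens) for cytotoxicity, read by MTT assay, with a stated time of 48 h (on this read-out higher numbers stand for weaker inhibition and lower numbers for stronger inhibition), are these:
compound 1 (`O=C1/C(=C\c2ccc(O)cc2)S/C(=N/c2ccccc2)N1Cc1ccncc1`) with 11800 nM
compound 2 (`CC(C)c1ccc(/C=C2/S/C(=N/c3ccccc3)N(Cc3ccncc3)C2=O)cc1`) with 32300 nM

Compound 2 at 32300 nM has the higher of these two numbers and is the weaker inhibitor. Compound 3 (`CCOc1cc(/C=C2/S/C(=N/c3ccccc3)N(Cc3ccncc3)C2=O)ccc1O`) differs from it by 3-ethoxy-4-hydroxyphenyl in place of 4-isopropylphenyl on a double-bonded chain carbon bound to a double-bonded ring carbon with 3-ethoxy-4-hydroxyphenyl in place of 4-isopropylphenyl on a double-bonded chain carbon bound to a double-bonded ring carbon. For the measured compounds named here, one measured step bears on this: a 2.7-fold higher number from compound 1 to compound 2 (0.44 log units; beyond the scatter) with isopropyl in place of hydroxy on an aromatic carbon, modest and beyond the scatter. Compound 3 carries a hydroxy group as compound 1 does, so a step of similar size in the reverse direction, toward a lower number, is expected in this assay here. Going by the values given here, no measured compound carries the ethoxy group, so the range stays wide. The expected step is a 2.3-fold lower number from compound 2 to compound 3 (0.36 log units; beyond the scatter) on this reasoning. The expected value for compound 3 is 14000 nM (estimated range 6000 nM to 32000 nM).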

Compound 3, half-maximal inhibitory concentration: 20400 nM
Compound 3: the middle estimate sits 1.5-fold (0.16 log units) below what was measured; the measured number falls inside the stated range.
By their numbers in this assay, from the lowest: compounds 1, 3 and 2 (each within the scatter of the next, the first and the last beyond it).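

In this assay, 3-ethoxy-4-hydroxyphenyl in place of 4-isopropylphenyl on a double-bonded chain carbon bound to a double-bonded ring carbon gives a 1.6-fold lower number from compound 2 to compound 3 (0.20 log units; within the scatter), so this change, unlike the earlier step between hydroxy and isopropyl, does not separate the two compounds. Ethoxy in place of hydrogen on an aromatic carbon gives a 1.7-fold higher number from compound 1 to compound 3 (0.24 log units; within the scatter), so adding this group to the hydroxy compound also yields no difference that can be read in this assay. No available evidence accounts for either step.

The compounds shown leave open whether the ethoxy group without the hydroxy group would give a number beyond the scatter from those of compound 1 and compound 2. They also leave open whether a longer chain, an amine or a carboxylic acid on the aromatic ring would do so.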